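Replacing methylsulfanyl in compound 2

This account rests on a few compounds, and the source may have more. Where it says the series, first, only, none or still open, it means among the compounds named here.

Compound 1 `CCOc1cc(/C=C/c2cc(SC)nc(N)n2)ccc1OC1CCCCO1`, compound 2 `CSc1cc(/C=C/c2ccc(OC3CCCCO3)cc2)nc(N)n1` and compound 3 `CSc1cc(/C=C/c2ccc(O)cc2)nc(N)n1` have been taken into an ADME assay on Vero cells (Chlorocebus sabaeus) for cytotoxicity, read by MTT assay, with a stated time of 72 h; a lower number here means that less compound is tolerated, a higher number that more compound is tolerated. There, compound 1 gives 248000 nM. Compound 2 gives 122000 nM, the lower of the two numbers available. The entry for compound 3 reads "not determined" (no result reported), so it offers no comparison. Compound 4 `COc1ccc(Nc2cc(/C=C/c3ccc(OC4CCCCO4)cc3)nc(N)n2)cc1` has yet to be measured. It carries (4-methoxyphenyl)amino in place of methylsulfanyl on an aromatic carbon of compound 2: (4-methoxyphenyl)amino in place of methylsulfanyl on an aromatic carbon.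

Going by the values given here, only one measured step is available, a 2.0-fold lower number from compound 1 to compound 2 (0.31 log units; beyond the scatter). It is modest and involves hydrogen in place of ethoxy, so it bears on the new change only indirectly, as a guide to the size of step seen so far. Among the compounds with values here, no measured compound carries the entering group, which leaves the direction a cautious judgement. A modest move towards a lower number is expected, an estimated 2.0-fold lower number from compound 2 to compound 4 (0.31 log units; beyond the scatter). For compound 4 the expected value in this assay is 60000 nM, with an estimated range of 15000 nM to 180000 nM.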

Compound 4, half-maximal cytotoxic concentration: 345000 nM
Estimate against measurement, compound 4: 5.8-fold (0.76 log units) below; measured number above the stated range.
By their numbers in this assay, from the lowest: compound 2; then compounds 1 and 4 (each within the scatter of the next).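

The exchange of methylsulfanyl for (4-methoxyphenyl)amino on the aromatic carbon next to the ring nitrogen gives a 2.8-fold higher number from compound 2 to compound 4 (0.45 log units; beyond the scatter) in this assay. Going by these compounds alone, this is the first measured change at this position, and it shows that the number there does not fall when a larger group with an aromatic ring and a hydrogen-bond donor enters; more compound is tolerated, not less. Nothing available explains this shift.

Within the data shown here, the entering group brings its ring, its amino hydrogen and its methoxy all at once, so the single step cannot say which of these parts goes with the higher number. From the compounds shown here alone, how a plain phenylamino group, a morpholine or a small alkylamine would read at this position also remains open.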